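The compounds below may be only part of what the source reports. "The series", "measured", "known", "first", "only" and "open" are said of these compounds alone.

Compound 1 `O=C(NCCCNc1cc(-c2cn(-c3ccccc3)nc2-c2cccc(O)c2)ccn1)Nc1ccc(F)cc1`: 3420 nM
Compound 2 `O=C(NCCCNc1cc(-c2cn(-c3ccccc3)nc2-c2cccc(O)c2)ccn1)Nc1cccc(C(F)(F)F)c1`: 6080 nM

Both compounds were tested in a functional assay on Malme-3M cells (Homo sapiens) for antiproliferative activity, read by sulforhodamine B assay, with a stated time of 48 h; on this read-out higher numbers stand for weaker inhibition of growth and lower numbers for stronger inhibition of growth. Compound 1 has one measured neighbour, compound 2, and the two values lie within the scatter of each other, so neither can be ranked above the other. The next compound, compound 3 `COc1cccc(-c2nn(-c3ccccc3)cc2-c2ccnc(NCCCNC(=O)Nc3ccc(F)cc3)c2)c1`, has not yet been measured in this assay. It keeps the core of compound 1 and differs from it by one change: methyl in place of hydrogen on an oxygen on an aromatic ring. In other words, a hydroxy group becomes methoxy, turning 3-hydroxyphenyl into 3-methoxyphenyl.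

Among the compounds with values here, the only measured step is a 1.8-fold higher number from compound 1 to compound 2 (0.25 log units; within the scatter). It replaces 4-fluorophenyl with 3-(trifluoromethyl)phenyl on an amide-type nitrogen, so it does not touch the hydroxy group. Within the data shown here, it shows only that one other change in this small set stayed within the scatter. Among the measured compounds shown here, the data contain no measured step at the hydroxy group, so they give no direction for this change, and the range must stay wide. No step beyond the scatter is expected.

The expected step is a 1.2-fold higher number from compound 1 to compound 3 (0.07 log units; within the scatter). For compound 3 the estimated value is 4000 nM, with an expected range from 1500 nM to 11000 nM.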

Compound 3, concentration for total growth inhibition: 10600 nM
Compound 3: the middle estimate sits 2.7-fold (0.42 log units) below what was measured; low and high end bracket the measured number.
By their numbers in this assay, from the lowest: compounds 1, 2 and 3 (each within the scatter of the next, the first and the last beyond it).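

In this assay the hydroxy group now has its first measured step, a 3.1-fold higher number from compound 1 to compound 3 (0.49 log units; beyond the scatter), so methyl in place of hydrogen on this oxygen goes with weaker inhibition of growth. The step is modest, but unlike the change on the amide-type nitrogen it lies beyond the scatter, which shows that this read-out responds to what sits on this oxygen, at least in this one pair with 4-fluorophenyl on the urea side of the molecule. Nothing available accounts for the difference, so the result stands as an observation only.

The compounds shown leave open whether the step depends on the methyl itself or on the loss of the hydrogen, and whether a longer chain on the same oxygen, such as ethoxy, or an amine in place of the hydroxy group would give a number closer to that of compound 1 or to that of compound 3. They also leave open whether the same step would appear with 3-(trifluoromethyl)phenyl on the amide-type nitrogen, as in compound 2.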